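A few compounds are considered here, and "the series" means these few. Any claim that something is new, unique, unknown or untested is made for them only; others in the source may bear on it.

Measured so far:
compound 1 `Cc1ccc(NC(=O)C2(C(=O)Nc3ccc(Nc4ncc5cc(C(=O)N(C)C)n(C6CCCC6)c5n4)cc3)CC2)cc1`: 90.6%
compound 2 `CN(C)C(=O)c1cc2cnc(Nc3ccc(NC(=O)C4(C(=O)Nc5cccc(C#N)c5)CC4)cc3)nc2n1C1CCCC1`: 73.6%

In a functional assay on A549 cells (Homo sapiens) for inhibition, read by CCK-8 assay, with a stated time of 72 h, tested at 10 uM (on this read-out lower numbers stand for less inhibition of growth and higher numbers for more inhibition of growth at the one concentration tested), compound 2 gives 73.6%, the lower of the two numbers. Compound 3 `CN(C)C(=O)c1cc2cnc(Nc3ccc(NC(=O)C4(C(=O)Nc5cccc(Br)c5)CC4)cc3)nc2n1C1CCCC1` has bromo in place of cyano on an aromatic carbon, meta to a large group: bromo in place of cyano on an aromatic carbon. For the measured compounds named here, only one measured step bears on this change, a number 17 percentage points lower from compound 1 to compound 2 (beyond the scatter), a modest fall that came with 3-cyanophenyl in place of 4-methylphenyl. Going by the values given here, no measured compound carries bromo, so that step is a loose guide. Since the cyano leaves again, part of that fall may be recovered in this assay, and a small rise, of about the size of the scatter, is expected. The expected change is a number 8.4 percentage points higher from compound 2 to compound 3 (within the scatter). For compound 3 the estimated value is 82%, in an expected range from 68% to 95%.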

Compound 3, percent growth inhibition at one concentration: 92.2%
For compound 3 the middle estimate is 10.2 percentage points below the measured one; the measured number falls inside the stated range.
By their numbers in this assay, from the lowest: compound 2; then compounds 1 and 3 (each within the scatter of the next).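

In this assay, bromo in place of cyano on the aromatic carbon gives a number 18.6 percentage points higher from compound 2 to compound 3 (beyond the scatter), which shows that this place tolerates a change of group and that the result depends on which group sits there. With a number 1.6 percentage points higher from compound 1 to compound 3 (within the scatter), the 3-bromophenyl and 4-methylphenyl compounds cannot be told apart, so among these three compounds the lower number goes with 3-cyanophenyl and not with a group at this place as such. No available evidence explains the difference between bromo and cyano here.

On these data alone, how an amine, a carboxylic acid or a methoxy group would read at this place remains open, as does whether a 4-bromophenyl group would match the 3-bromophenyl group. As far as these compounds go, whether compound 1 and compound 3 would separate at other concentrations is also open.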